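The source may report more compounds than this note shows. Statements on the series, on what has been measured and on what is new or still open speak of the compounds shown alone.

Of the compounds shown here, two from this series have so far been tested in a functional assay on the whole organism for inhibition, with Rattus norvegicus as the target; a lower number here means that less compound is needed, a higher number that more compound is needed for the effect. Compound 1 `CC1C/C(=N\Nc2ccccc2)c2ncc(C(=O)O)c(=O)n2C1` gives 5.7 umol/kg in this assay, and compound 2 `CC1CC/C(=N\Nc2cccc(Cl)c2)c2ncc(C(=O)O)c(=O)n21` gives 0.6 umol/kg there. Compound 2 therefore stands at the lowest of the two numbers, and the gap to compound 1, the nearest neighbour, lies beyond the usual scatter.

Compound 3 `CC1CC/C(=N\Nc2ccc(O)cc2)c2ncc(C(=O)O)c(=O)n21` has not yet been measured in this assay. It differs from compound 2 by a single change: 4-hydroxyphenyl in place of 3-chlorophenyl on an amine nitrogen. Within the data shown here, no pair of measured compounds shows this exchange, so nothing in the data gives the size of the step directly. Without such a reference, a modest rise in the number is expected rather than a large one, and a step no bigger than the scatter cannot be ruled out. The expected step from compound 2 to compound 3 in this assay is a 3.3-fold higher number from compound 2 to compound 3 (0.52 log units; beyond the scatter). For compound 3 the estimate in this assay is 2 umol/kg, with a range from 0.5 umol/kg to 8 umol/kg.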

Compound 3, dose for 50% inhibition: 1.7 umol/kg
Compound 3: the middle estimate sits 1.2-fold (0.07 log units) above what was measured; the measured number falls inside the stated range.
By their numbers in this assay, from the lowest: compound 2; then compound 3; then compound 1.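

Among these compounds, the exchange of 3-chlorophenyl for 4-hydroxyphenyl on the amine nitrogen gives a 2.8-fold higher number from compound 2 to compound 3 (0.45 log units; beyond the scatter) in this assay and so puts a first size on a change at this position. The position accepts a group carrying a hydrogen-bond donor and acceptor, at a cost that is modest yet beyond the scatter. No accompanying measurement bears on what lies behind this step.

The change replaces the chlorine with a hydroxyl and also moves the substituent, and the compounds shown do not separate these two differences, which 4-chlorophenyl or 3-hydroxyphenyl on the same nitrogen could do. From the compounds shown here alone, how an unsubstituted phenyl, 4-methoxyphenyl or 4-aminophenyl would read on the core of compound 2 also remains open.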